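Removing the Iodo Group from Compound 3

A few compounds are considered here, and "the series" means these few. Any claim that something is new, unique, unknown or untested is made for them only; others in the source may bear on it.

Compound 1 `C=C[C@@](C)(/C=C/c1ccc(OC(=O)CCCC)cc1)CCC=C(C)C`: 38%
Compound 2 `C=C[C@@](C)(/C=C/c1ccc(OC(=O)CCCCC)cc1)CCC=C(C)C`: 58%
Compound 3 `CC[C@](C)(CCCC(C)C)CCc1ccc(O)c(I)c1`: 12%

All three values come from a functional assay on A549 cells (Homo sapiens) for inhibition, with a stated time of 48 h, tested at 50 uM; a lower number here means less inhibition of growth, a higher number more inhibition of growth at the concentration tested. In this assay, compound 3 gives 12%, the lowest number of the three and beyond the scatter from both compound 1 and compound 2.

The next compound to be tested is compound 4 `CC[C@](C)(CCCC(C)C)CCc1ccc(O)cc1`. It differs from compound 3 at one place: hydrogen in place of iodo on an aromatic carbon. In words, this is hydrogen in place of iodo on an aromatic carbon, ortho to a hydroxy group.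

Within the data shown here, only one step has been measured between two closely matched compounds: a number 20 percentage points higher from compound 1 to compound 2 (beyond the scatter). That step concerns a saturated chain on a carbonyl, not the iodo group, so it gives only a rough idea of how large a single small change can be here. Among the measured compounds shown here, no measured pair shows what removing iodo does. However, compound 3 sits low at 12%, which leaves more room for the number to rise than to fall. A modest rise is therefore the tentative expectation, with real uncertainty about its direction.

The expected change is a number 16 percentage points higher from compound 3 to compound 4 (beyond the scatter). The estimated value for compound 4 is 28%, with an expected range of 8% to 55%.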

Compound 4, percent growth inhibition at one concentration: 49%
Beside the measured number, compound 4's estimate is 21 percentage points below it; measured number inside the range.
By their numbers in this assay, from the lowest: compound 3; then compound 1; then compounds 4 and 2 (each within the scatter of the next).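

Among these compounds, replacing the iodo group with hydrogen on this aromatic carbon, ortho to a hydroxy group, gives a number 37 percentage points higher from compound 3 to compound 4 (beyond the scatter) in this assay and so shows for the first time that this position responds strongly to a change. Only one heavy atom leaves, with no ring and no net charge involved, so a very small edit to the structure is enough to shift growth inhibition by a large amount. Among the compounds shown here, the direction is also now clear for this pair: the compound without iodo is the one that inhibits growth more, although nothing measured so far explains why this single change has such an effect.

Going by these compounds, with only iodo and hydrogen seen at this aromatic carbon, it remains open where a fluoro, chloro or methyl group there would fall relative to compound 3 and compound 4. The role of the neighbouring hydroxy group is open too, since compound 3 and compound 4 both carry it, and a methoxy group in its place would show whether the effect of removing iodo still holds.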